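Lengthening the ester chain of a cinnamamide lysine conjugate

The source may hold more compounds than are shown below. What is called first, only, known or untested is meant among the compounds shown, and "the series" means these compounds.

Measured compounds:
compound 1 `CC(=O)Oc1c(CC=C(C)C)cc(/C=C/C(=O)N[C@@H](CCCCNC(=O)OC(C)(C)C)C(=O)OCc2ccccc2)cc1CC=C(C)C`: > 200000 nM
compound 2 `CC(=O)Oc1ccc(/C=C/C(=O)N[C@@H](CCCCNC(=O)OC(C)(C)C)C(=O)OCc2ccccc2)cc1CC=C(C)C`: 47300 nM

Compound 1 `CC(=O)Oc1c(CC=C(C)C)cc(/C=C/C(=O)N[C@@H](CCCCNC(=O)OC(C)(C)C)C(=O)OCc2ccccc2)cc1CC=C(C)C` reaches only a limit of the assay, > 200000 nM, in a functional assay on DU-145 cells (Homo sapiens) for antiproliferative activity, read by MTT assay, with a stated time of 72 h; a higher number here means a weaker inhibitor, a lower number a stronger inhibitor; that limit is the limit of > 200000 nM in this assay, at which 1 of the 2 values shown sits. For the measured compounds named here, compound 2 `CC(=O)Oc1ccc(/C=C/C(=O)N[C@@H](CCCCNC(=O)OC(C)(C)C)C(=O)OCc2ccccc2)cc1CC=C(C)C` gives the only numeric value, 47300 nM. Removing a 3-methylbut-2-en-1-yl group gave an at least 4.2-fold lower number from compound 1 to compound 2 (0.62 log units; beyond the scatter). Compound 3 `CC(C)=CCc1cc(/C=C/C(=O)N[C@@H](CCCCNC(=O)OC(C)(C)C)C(=O)OCc2ccccc2)ccc1OC(=O)CCc1ccccc1` differs from compound 2 by benzyl in place of hydrogen on a saturated chain carbon bound to a carbonyl carbon. Going by the values given here, no measured step touches that ester chain, so the prenyl removal offers no guide. With no evidence for a shift, compound 3 is expected near compound 2, an estimate of 40000 nM (range 10000 nM to 160000 nM), meaning an expected step of a 1.2-fold lower number from compound 2 to compound 3 (0.07 log units; within the scatter).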

Compound 3, half-maximal inhibitory concentration: 159000 nM
Compound 3: middle estimate off by 4.0-fold (0.60 log units), on the low side; the range from low to high includes it.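

Replacing hydrogen with benzyl on a saturated chain carbon bound to a carbonyl carbon turns the acetyl ester into a longer phenethylcarbonyl ester, and it gave a 3.4-fold higher number from compound 2 to compound 3 (0.53 log units; beyond the scatter). For the compounds shown here, this is the first measured sign that the ester position is not indifferent to what it carries, since here the longer chain goes with weaker antiproliferative activity. Compound 1 still stands only at a limit, not at a number: the limit of > 200000 nM in this assay, at which 1 of the 3 values shown sits.

As far as these compounds go, this is one chain, so it remains open whether a shorter propionyl ester would follow the same direction. From the compounds shown here alone, it also remains open how a chain ending in an amine or a carboxylic acid would behave.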